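The compounds below may be only part of what the source reports. "The series", "measured", "known", "first", "only" and "open" are said of these compounds alone.

Measured so far:
compound 1 `COc1ccc(OC)c2c1c(C(=O)/C=C(\O)C(=O)O)cn2Cc1ccc(F)cc1`: 213000 nM
compound 2 `COc1cccc2c(C(=O)/C=C(\O)C(=O)O)cn(Cc3ccc(F)cc3)c12`: 82900 nM

In an ADME assay on MT4 cells (Homo sapiens) for cytotoxicity, read by MTT assay (on this read-out lower numbers stand for higher toxicity in this test and higher numbers for lower toxicity in this test), compound 1 gives 213000 nM, the higher of the two numbers, so it is the less toxic of the pair in this test. Its nearest and only neighbour is compound 2.

The next compound to read is compound 3 `COc1cccc2c1c(C(=O)/C=C(\O)C(=O)O)cn2Cc1ccc(F)cc1`, still unmeasured. The change is hydrogen in place of methoxy on an aromatic carbon, para to a methoxy group.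

Within the data shown here, only one measured step bears on this, a 2.6-fold lower number from compound 1 to compound 2 (0.41 log units; beyond the scatter). It is a modest step and the same kind of replacement, made at the other methoxy group of compound 1. A single precedent at a different carbon transfers only loosely, so the direction is held with more confidence than the size. In this assay a modest move to a lower number is expected again, of similar size and beyond the scatter, though a smaller one would not surprise.

The expected step is a 2.2-fold lower number from compound 1 to compound 3 (0.35 log units; beyond the scatter).

Compound 3 is estimated at 95000 nM, with an expected range of 40000 nM to 220000 nM.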

Compound 3, half-maximal cytotoxic concentration: 41100 nM
Compound 3: the middle estimate sits 2.3-fold (0.36 log units) above what was measured; measured number inside the range.
By their numbers in this assay, from the lowest: compounds 3 and 2 (each within the scatter of the next); then compound 1.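

Hydrogen in place of the methoxy para to a methoxy group gives a 5.2-fold lower number from compound 1 to compound 3 (0.71 log units; beyond the scatter) in this assay and so repeats the direction of a 2.6-fold lower number from compound 1 to compound 2 (0.41 log units; beyond the scatter) at the other methoxy group. Each of the two single replacements has now been read, and compounds 2 and 3 stand within the scatter of each other, so they cannot be ranked in this test, while compound 1, which carries both methoxy groups, is the least toxic of the three. Nothing measured here gives a reason for either step.

On these data alone, it remains open whether the higher number of compound 1 depends on methoxy itself at these two carbons or would hold with another group there, such as hydroxyl, fluorine or the longer ethoxy chain. Also open, as far as these compounds go, is how far the number would move with hydrogen at both carbons, which would show whether the two replacements add up or overlap.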